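Benzimidazole acid in place of a methyl ester

The compounds below may be only part of what the source reports. "The series", "measured", "known", "first", "only" and "open" are said of these compounds alone.

Compound 1 `COC(=O)c1ccc(CN2CCC[C@H](O[C@H](CO)c3cc(Cl)cc(Cl)c3)[C@@H]2c2ccccc2)c(C)c1` was tested in an assay on isolated protein for activation of cGMP-dependent protein kinase 1 (Homo sapiens), read by ADP-Glo, with stated times of 30 min and 2 h; a lower number here means that less compound is needed, a higher number that more compound is needed for the effect. In this assay compound 1 gives > 200000 nM, which is a limit of the assay and not a number. Compound 3 `Cc1cc(C(=O)O)ccc1CN1CCC[C@H](O[C@H](CO)c2ccccc2)[C@@H]1c1ccccc1` is also known here. In this assay compound 3 gives > 200000 nM, again a limit of the assay. Compound 2 `Cc1cc(C(=O)O)ccc1CN1CCC[C@H](O[C@H](CO)c2cc(Cl)cc(Cl)c2)[C@@H]1c1cccc(F)c1` has no result in this assay, "nd" (no result reported). Of the three values shown, two sit at the limit (the limit of > 200000 nM in this assay, at which 2 of the 3 values shown sit), so compound 1 stands at the edge of what the assay can report, with nothing beside it to rank against.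

Compound 4 `O=C(O)c1ccc2nc(CN3CCC[C@H](O[C@H](CO)c4cc(Cl)cc(Cl)c4)[C@@H]3c3ccccc3)[nH]c2c1` carries a group of 12 heavy atoms (8 carbon, 2 nitrogen, 2 oxygen; one five-membered aromatic ring with 2 hetero atoms, one six-membered aromatic ring of carbon only) in place of a group of 11 heavy atoms (9 carbon, 2 oxygen; one six-membered aromatic ring of carbon only), on a saturated chain carbon bound to an amine nitrogen in a ring. Going by the values given here, no step between two measured compounds is known here, so the direction of this change cannot be read from a measured pair. Given that compound 1 gives > 200000 nM and compound 3 gives > 200000 nM at the same limit, compound 4 is expected to stay near that limit, and the estimated step from compound 1 to compound 4 is an at least 1.3-fold lower number from compound 1 to compound 4 (0.12 log units; that floor lies within the scatter). Compound 4 is thus estimated at 150000 nM, with a range from 20000 nM to 300000 nM.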

Compound 4, half-maximal effective concentration: 43000 nM
For compound 4 the middle estimate is 3.5-fold (0.54 log units) above the measured one; low and high end bracket the measured number.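

Compound 4 is the first compound shown to give a number rather than a limit in this assay, so this place on the saturated chain carbon bound to an amine nitrogen in a ring can alter the read-out. Placing the group of 12 heavy atoms there instead of the group of 11 heavy atoms gives an at least 4.6-fold lower number from compound 1 to compound 4 (0.66 log units; beyond the scatter), and the true size of this step stays open, as the value for compound 1 is a limit. Two compounds shown still stand at the limit: the limit of > 200000 nM in this assay, at which 2 of the 4 values shown sit.

The change swaps the ring system and turns the methyl ester into a carboxylic acid in one step, so the compounds shown do not tell which part accounts for it. On these data alone, how an amide or a tetrazole in place of that carboxylic acid would read also remains open.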